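From Chlorophenyl to Difluorophenyl: An Expected Small Shift

A few compounds are considered here, and "the series" means these few. Any claim that something is new, unique, unknown or untested is made for them only; others in the source may bear on it.

Of the compounds shown here, two sharing one core have been measured in an assay on isolated protein for inhibition of serine/threonine-protein kinase PAK 4 (Homo sapiens), read by HTRF, with a stated time of 60 min; a lower number here means a stronger inhibitor, a higher number a weaker inhibitor. Compound 1 `Cc1cc(Nc2nc(NCc3ccccc3F)nc3[nH]ncc23)n[nH]1` gives 389 nM. Compound 2 `Cc1cc(Nc2nc(NCc3ccc(Cl)cc3)nc3[nH]ncc23)n[nH]1` gives 515 nM, the higher of the two numbers, although the step of a 1.3-fold higher number from compound 1 to compound 2 (0.12 log units; within the scatter) stays within the scatter, so no order between them can be claimed. Compound 3 `Cc1cc(Nc2nc(NCc3ccc(F)cc3F)nc3[nH]ncc23)n[nH]1` has not yet been measured. It differs from compound 2 by 2,4-difluorophenyl in place of 4-chlorophenyl on a saturated chain carbon bound to a nitrogen on an aromatic ring.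

Within the data shown here, only one measured step bears on this change: a 1.3-fold higher number from compound 1 to compound 2 (0.12 log units; within the scatter), which exchanged 2-fluorophenyl for 4-chlorophenyl at the same place and moved the number by an amount that repeated measurements would not distinguish. Compound 3 carries fluorine at both the position present in compound 1 and the position that holds chlorine in compound 2, so the available step gives no reason to expect a move beyond the scatter in either direction in this assay. Compound 3 is therefore estimated at 420 nM, with a range of 200 nM to 900 nM, which corresponds to an expected step of a 1.2-fold lower number from compound 2 to compound 3 (0.09 log units; within the scatter).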

Compound 3, half-maximal inhibitory concentration: 96.1 nM
The estimate for compound 3 lay 4.4-fold (0.64 log units) above the measured number; measured number outside the range, below it.
By their numbers in this assay, from the lowest: compound 3; then compounds 1 and 2 (each within the scatter of the next).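

In this assay, the place on a saturated chain carbon bound to a nitrogen on an aromatic ring now proves able to move the number beyond the scatter, which compound 1 and compound 2 had not shown, since a 1.3-fold higher number from compound 1 to compound 2 (0.12 log units; within the scatter) stayed within it; 2,4-difluorophenyl in place of 4-chlorophenyl gives a 5.4-fold lower number from compound 2 to compound 3 (0.73 log units; beyond the scatter). The smallest change in the set, fluoro in place of hydrogen on an aromatic carbon, gives a 4.0-fold lower number from compound 1 to compound 3 (0.61 log units; beyond the scatter), so a single exchange on this ring is enough for a step beyond the scatter, and the identity and pattern of the ring's substituents matter here in a way the first pair could not reveal. Nothing available bears on why the number falls with this change.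

The compounds shown leave open whether the fall needs both fluorines, as 4-fluorophenyl alone is not among them to separate the contribution of each. They also leave open how far this place tolerates other groups, such as a methoxy or a nitrile on the ring, or a longer chain in place of the present one.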